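Unmasking the Ring Nitrogen: From Compound 2 to Compound 3

The compounds below may be only part of what the source reports. "The series", "measured", "known", "first", "only" and "open" are said of these compounds alone.

Compound 1 `N=C(Nc1cccc(C(F)(F)F)c1)c1cc2c(-c3ccccc3)n[nH]c2cn1` was examined in a functional assay on HT-1080 cells (Homo sapiens) for cytotoxicity, read by MTT assay, with a stated time of 72 h (on this read-out lower numbers stand for stronger inhibition and higher numbers for weaker inhibition), where compound 1 gives 24600 nM. Compound 2 `COc1ccc(Cn2nc(-c3ccccc3)c3cc(C(=N)Nc4cccc(C(F)(F)F)c4)nc(NC4CCCCC4)c32)cc1` shares the amidine and the trifluoromethyl-bearing aryl of compound 1 but carries a cyclohexylamino group and a 4-methoxybenzyl on an aromatic nitrogen; in this assay compound 2 has no single number, its result being "not determined" (no result reported). Compound 3 `N=C(Nc1cccc(C(F)(F)F)c1)c1cc2c(-c3ccccc3)n[nH]c2c(NC2CCCCC2)n1` arises from compound 2 through (hydrogen in place of 4-methoxybenzyl on an aromatic nitrogen). Among the measured compounds shown here, nothing measured bridges the two, and the only number in hand, that of compound 1, belongs to a compound lacking the cyclohexylamino group, so the step from compound 2 to compound 3 in this assay cannot be sized from data; the account expects no shift beyond the usual scatter in either direction. Compound 3 is therefore estimated to give about 12000 nM in this assay, with a range from 2500 nM to 50000 nM.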

Compound 3, half-maximal inhibitory concentration: 21200 nM
Compound 3: the middle estimate sits 1.8-fold (0.25 log units) below what was measured, within the range that was stated.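

In this assay, cyclohexylamino in place of hydrogen on an aromatic carbon gives a 1.2-fold lower number from compound 1 to compound 3 (0.06 log units; within the scatter), a step within the scatter, so the compounds shown give the first reading of this group on the shared core and no separation from the hydrogen. As far as these compounds go, the step that removes the 4-methoxybenzyl from the aromatic nitrogen cannot be read, as compound 2 has no reported result, and the effect of that group on this read-out remains unknown. No supporting measurement bears on why the cyclohexylamino group leaves the two values within the scatter.

The compounds shown leave open whether a morpholine or a smaller amine such as methylamino on that aromatic carbon would give a step beyond the scatter. They also leave open how a methyl group in place of hydrogen on the aromatic nitrogen would read.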